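Switching the aryl group on the oxime carbon

A few compounds are considered here, and "the series" means these few. Any claim that something is new, unique, unknown or untested is made for them only; others in the source may bear on it.

Compound 2 `Cc1cc(C)cc(/C(CCN2CCN(c3ccccn3)CC2)=N/O)c1` is the higher of the two numbers measured in a functional assay on HEK293 cells with D(4) dopamine receptor (Homo sapiens) as the target, read by FLIPR (on this read-out lower numbers stand for an effect already at smaller amounts and higher numbers for an effect only at larger amounts of compound), where compound 2 gives 45.8 nM. Among the compounds with values here, its nearest neighbour is compound 1 `Cc1cccc(/C(CCN2CCN(c3ccccn3)CC2)=N/O)c1`, which in this assay gives 2.3 nM; the only step among the measured compounds is a 20-fold higher number from compound 1 to compound 2 (1.30 log units; beyond the scatter). Compound 3 `O/N=C(\CCN1CCN(c2ccccn2)CC1)c1ccc(F)cc1F` differs from compound 2 by 2,4-difluorophenyl in place of 3,5-dimethylphenyl on a carbon with a double bond to nitrogen. Within the data shown here, no measured step concerns fluorine on this ring; the single step available shows only that one added methyl raised the number strongly, and compound 3 carries no methyl at all. On that basis compound 3 is expected to fall back toward compound 1, that is a lower number by a 5.7-fold lower number from compound 2 to compound 3 (0.76 log units; beyond the scatter), though the two fluorines leave a wide uncertainty. The estimate for compound 3 in this assay is 8 nM, within a range from 1.5 nM to 50 nM.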

Compound 3, half-maximal effective concentration: 8.9 nM
Compound 3: middle estimate off by 1.1-fold (0.05 log units), on the low side, and the stated range covers the measured number.
By their numbers in this assay, from the lowest: compound 1; then compound 3; then compound 2.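

The aryl group on a carbon with a double bond to nitrogen can now be read as an exchange of the whole ring and not only as one added methyl. In this assay the change to 2,4-difluorophenyl gives two steps (a 5.1-fold lower number from compound 2 to compound 3 (0.71 log units; beyond the scatter)) and (a 3.9-fold higher number from compound 1 to compound 3 (0.59 log units; beyond the scatter)), which place this ring between 3-methylphenyl and 3,5-dimethylphenyl, so a ring with no methyl does not lose the effect at small amounts, though it does not match 3-methylphenyl. No measurement on these compounds offers a reason for this order.

From the compounds shown here alone, the exchange removes methyl and adds fluorine at once, so the share of each stays open. Also open, going by these compounds, is what a single fluorine, a chlorine, a methoxy group or a plain phenyl would give at this position.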